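Cytotoxicity of three chalcone-type pyranones and a methyl analogue

The source may hold more compounds than are shown below. What is called first, only, known or untested is meant among the compounds shown, and "the series" means these compounds.

Compound 1, `Cc1cc(O)c(C(=O)/C=C/c2cccc(O)c2)c(=O)o1`: > 100000 nM
Compound 2, `Cc1cc(O)c(C(=O)/C=C/c2ccc(C(F)(F)F)cc2)c(=O)o1`: 100000 nM
Compound 3, `Cc1cc(O)c(C(=O)/C=C/c2cc(Br)cs2)c(=O)o1`: 100000 nM

Three compounds sharing one core were tested in an ADME assay on HEK293 cells (Homo sapiens) for cytotoxicity, read by MTT assay; on this read-out lower numbers stand for stronger inhibition and higher numbers for weaker inhibition. The value of compound 1 in this assay, > 100000 nM, is a limit of the assay and not a number. Compound 2 gives 100000 nM in this assay, and compound 3 gives 100000 nM. On these numbers compound 2 stands level with compound 3 at the digits shown, with no change between them within the usual scatter; the one further value, that of compound 1, sits at the limit, (the limit of > 100000 nM in this assay, at which 1 of the 3 values shown sits).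

Compound 4, `Cc1ccc(/C=C/C(=O)c2c(O)cc(C)oc2=O)cc1`, has not yet been measured in this assay. It differs from compound 2 at a single site: methyl in place of trifluoromethyl on an aromatic carbon.

For the measured compounds named here, no step between measured compounds that differ in one place is available, so the size of this step cannot be read from the set. Across compounds 1, 2 and 3 the values all cluster at the same high level, and compound 4 is therefore expected to show no step beyond the scatter, with no change at the digits printed from compound 2 to compound 4 (within the scatter). For compound 4 the estimated value in this assay is 100000 nM, within a range from 50000 nM to 200000 nM.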

Compound 4, half-maximal inhibitory concentration: > 100000 nM
Compound 4 gave a limit, no number (the forecaster's own chance of this, stated with the estimate: 50%); the middle value sits exactly at the limit.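

In this assay, methyl in place of trifluoromethyl on an aromatic carbon, para to a large group, gives a number no lower from compound 2 to compound 4 (the limit leaves the size open). For the compounds shown here, this is the first step in the set between two measured compounds that differ in one place, and it shows that at this position the change from four heavy atoms to one does not bring the value to a lower number. The value of compound 4, > 100000 nM, is a limit of the assay and not a number, and it is now the second value in the set to rest there: the limit of > 100000 nM in this assay, at which 2 of the 4 values shown sit.

From the compounds shown here alone, the size of the step therefore stays unknown, and the set shows only that neither trifluoromethyl nor methyl on this aromatic carbon gives a value lower than that of compound 2. Going by these compounds, whether an amine, a carboxylic acid or a longer chain on the same carbon would give a clearly lower number in this assay remains open.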